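This account rests on a few compounds, and the source may have more. Where it says the series, first, only, none or still open, it means among the compounds named here.

Compounds measured in an ADME assay on Vero cells (Chlorocebus sabaeus) for cytotoxicity; on this read-out higher numbers stand for lower toxicity in this test and lower numbers for higher toxicity in this test:

Compound 1, `Fc1ccc(-c2nc3c(NC4CC4)cccn3c2-c2ccnc(NC3CCCC3)n2)cc1`, gives 33000 nM.
Compound 2, `CCCCNc1cccn2c(-c3ccnc(NC4CCCC4)n3)c(-c3ccc(F)cc3)nc12`, gives 32000 nM.
Compound 3, `Fc1ccc(-c2nc3c(C4CCCC4)cccn3c2-c2ccnc(NC3CCCC3)n2)cc1`, gives only a limit of the assay, > 40000 nM.

Compound 3 therefore stands without a number of its own: it sits at the limit of > 40000 nM in this assay, at which 1 of the 3 values shown sits, and nothing shows how far past that boundary it lies. Compound 4, `Fc1ccc(-c2nc3ccccn3c2-c2ccnc(NC3CCCC3)n2)cc1`, is not yet measured. It differs from compound 3 in one place: hydrogen in place of cyclopentyl on an aromatic carbon.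

Two measured steps arrive at compound 3 from a neighbour and so bear on this change. Both are known only as floors: an at least 1.2-fold higher number from compound 1 to compound 3 (0.08 log units; that floor lies within the scatter), and an at least 1.2-fold higher number from compound 2 to compound 3 (0.09 log units; that floor lies within the scatter). Each floor lies within the scatter, so nothing here shows that the cyclopentyl on that aromatic carbon moves the read-out at all. Taking it away to leave a hydrogen is therefore expected to give no step beyond the scatter, neither up nor down, and the expected step is a number no higher from compound 3 to compound 4 (the limit leaves the size open). On that basis compound 4 is estimated at 40000 nM, with a range from 20000 nM to 80000 nM.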

Compound 4, half-maximal cytotoxic concentration: > 40000 nM
Compound 4: a limit, no number; the forecaster's own chance of this, stated with the estimate: 50%; the middle value lies on the limit itself.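

Hydrogen on this aromatic carbon leaves the read-out in this assay at the same boundary as the cyclopentyl of compound 3, so the result now holds with no group at this position at all: the limit of > 40000 nM in this assay, at which 2 of the 4 values shown sit.

Set against the compounds with an amino group on this carbon, the hydrogen gives an at least 1.2-fold higher number from compound 2 to compound 4 (0.09 log units; that floor lies within the scatter), and an at least 1.2-fold higher number from compound 1 to compound 4 (0.08 log units; that floor lies within the scatter), so neither floor shows that removing the amino group changes anything. The step between compound 3 and compound 4 cannot be read, as both values are limits of the assay.

As far as these compounds go, how far compound 3 and compound 4 lie past that limit stays open. Also open, from the compounds shown here alone, is what a carboxylic acid, or a longer chain ending in an amine, on this aromatic carbon would do to the read-out.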